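The source may report more compounds than this note shows. Statements on the series, on what has been measured and on what is new or still open speak of the compounds shown alone.

Measured so far in a functional assay on HCT-15 cells (Homo sapiens) for cytotoxicity, read by CCK-8 assay and cell counting, with a stated time of 2 days; a higher number here means a weaker inhibitor, a lower number a stronger inhibitor:
- compound 1, `Oc1cccc(-c2cc(-c3ccc(Cl)cc3)nc(-c3ccccn3)c2)c1`, gives 13500 nM
- compound 2, `Oc1cccc(-c2cc(-c3ccccc3)nc(-c3ccc(Cl)cc3)c2)c1`, gives 8110 nM
- compound 3, `Oc1ccc(-c2cc(-c3ccccc3)nc(-c3ccc(Cl)cc3)c2)cc1`, gives 6920 nM

Three compounds sit on a shared core, and all three values lie within the scatter of one another; none can be called the strongest or weakest. The change from compound 2 to compound 3 is 4-hydroxyphenyl in place of 3-hydroxyphenyl on an aromatic carbon, and it gave a 1.2-fold lower number from compound 2 to compound 3 (0.07 log units; within the scatter). The change from compound 2 to compound 1 is pyridin-2-yl in place of phenyl on an aromatic carbon, and it gave a 1.7-fold higher number from compound 2 to compound 1 (0.22 log units; within the scatter).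

Compound 4, `Oc1ccc(-c2cc(-c3ccc(Cl)cc3)nc(-c3ccccn3)c2)cc1`, is not yet measured. It differs from compound 3 by pyridin-2-yl in place of phenyl on an aromatic carbon. This is the same kind of change as that from compound 2 to compound 1, though the surroundings differ: in the earlier case the place is meta to a 3-hydroxyphenyl group, here it is meta to a 4-hydroxyphenyl group.

Because the same kind of change gave a 1.7-fold higher number from compound 2 to compound 1 (0.22 log units; within the scatter) in this assay, compound 4 is expected to show a 1.7-fold higher number from compound 3 to compound 4 (0.22 log units; within the scatter). Compound 4 is thus estimated at 11500 nM, with a likely range of 5500 nM to 24000 nM.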

Compound 4, half-maximal inhibitory concentration: 21300 nM
The estimate for compound 4 lay 1.9-fold (0.27 log units) below the measured number; measured number inside the range.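

In this assay, pyridin-2-yl in place of phenyl gave a 3.1-fold higher number from compound 3 to compound 4 (0.49 log units; beyond the scatter), and the size of this step does not differ beyond the scatter from that of the same change on the other core: the same change on two cores in this assay, a 1.7-fold higher number (0.22 log units; within the scatter) from compound 2 to compound 1 and a 3.1-fold higher number (0.49 log units; beyond the scatter) from compound 3 to compound 4, 1.8-fold (0.27 log units) apart, within the scatter of two such steps
The second change, 4-hydroxyphenyl in place of 3-hydroxyphenyl, gave a 1.6-fold higher number from compound 1 to compound 4 (0.20 log units; within the scatter), and it too stays within the scatter when set beside its earlier counterpart: the same change on two cores in this assay, a 1.2-fold lower number (0.07 log units; within the scatter) from compound 2 to compound 3 and a 1.6-fold higher number (0.20 log units; within the scatter) from compound 1 to compound 4, 1.8-fold (0.27 log units) apart, within the scatter of two such steps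
Going by these compounds alone, both changes therefore carry from one core to the other without a resolved difference, but this does not show that their effects are equal or general, since each comparison rests on a single pair of steps and only the step to compound 4 lies beyond the scatter.

The compounds shown leave open whether the pyridin-2-yl step would hold if the hydroxyl were replaced by an amine or a carboxylic acid. They also leave open how pyridin-3-yl would compare with pyridin-2-yl, and what would follow from replacing the chlorine of the 4-chlorophenyl group with fluorine or a methoxy group.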